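Replacing the Furan in Compound 1

The compounds below may be only part of what the source reports. "The series", "measured", "known", "first", "only" and "open" are said of these compounds alone.

Measured in a functional assay on HL-60 cells (Homo sapiens) for antiproliferative activity, read by XTT assay, with a stated time of 72 h; a higher number here means a weaker inhibitor, a lower number a stronger inhibitor:
Compound 1 `C=C(C)CC[C@]1(C)C2=CCC[C@](C)(C[C@H](O)c3ccoc3)[C@H]2CC[C@H]1C`: 28700 nM
Compound 2 `C=C(C)CCC[C@]1(C)C2=CCC[C@](C)(C[C@@H](OC(C)=O)C3=CC(=O)OC3O)[C@H]2CC[C@H]1C`: 3200 nM

Only these two compounds have been measured so far. Compound 1, at 28700 nM, has the higher number and so is the weaker inhibitor, while compound 2 gives 3200 nM, a gap beyond the usual scatter. Compound 3 `C=C(C)CC[C@]1(C)C2=CCC[C@](C)(C[C@H](O)C3=CC(=O)OC3O)[C@H]2CC[C@H]1C` has not yet been measured. It departs from compound 1 in one place: a group of 7 heavy atoms (4 carbon, 3 oxygen; one five-membered non-aromatic ring with 1 hetero atom) in place of a group of 5 heavy atoms (4 carbon, 1 oxygen; one five-membered aromatic ring with 1 hetero atom), on a saturated chain carbon bound to an oxygen on a saturated carbon and a saturated chain carbon. A five-membered non-aromatic ring with 1 hetero atom takes the place of furan-3-yl, on a saturated chain carbon bound to an oxygen on a saturated carbon and a saturated chain carbon.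

For the measured compounds named here, no measured pair isolates this change, so any forecast is tentative. Compound 2, which also lacks furan-3-yl and carries a five-membered non-aromatic ring, gives 3200 nM, but it differs from compound 3 elsewhere as well. In this assay, a step beyond the scatter towards a lower number is therefore expected. The expected size is a 4.8-fold lower number from compound 1 to compound 3 (0.68 log units; beyond the scatter). For compound 3 the estimate is 6000 nM, with an expected range from 2500 nM to 15000 nM.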

Compound 3, half-maximal inhibitory concentration: 3200 nM
Compound 3: the middle estimate sits 1.9-fold (0.27 log units) above what was measured, within the range that was stated.
By their numbers in this assay, from the lowest: compounds 2 and 3 (each within the scatter of the next); then compound 1.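

In this assay, for the compounds shown here, the earlier compounds gave no measured pair for this change, whereas a 9.0-fold lower number from compound 1 to compound 3 (0.95 log units; beyond the scatter) now isolates it, with the core of compound 1 and the rest of its structure unchanged. This shows that the place on a saturated chain carbon bound to an oxygen on a saturated carbon and a saturated chain carbon is sensitive to the group it carries: the five-membered non-aromatic ring with 1 hetero atom gives a lower number than furan-3-yl, in a step that lies beyond the usual scatter. Nothing available here explains why the number falls.

With only this single exchange at the position, the compounds shown cannot say which feature of the entering ring accounts for the step, out of its hydrogen-bond donor, its added acceptors or its 2 double bonds outside aromatic rings. They also leave open how a phenyl ring or a carboxylic acid in place of furan-3-yl would read in this assay, and whether a methoxy group on the new ring in place of its hydroxyl would keep the lower number.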